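Swapping a Methoxy for Bromo on an Acylguanidine Core

A few compounds are considered here, and "the series" means these few. Any claim that something is new, unique, unknown or untested is made for them only; others in the source may bear on it.

Compound 2 `COc1ccc(C(=O)N=C(N)N)cc1S(C)(=O)=O` gives 270 nM in a functional assay for inhibition of sodium/hydrogen exchanger (Oryctolagus cuniculus) (a higher number here means a weaker inhibitor, a lower number a stronger inhibitor), the higher of the two numbers seen so far. Within the data shown here, compound 1 `Cc1ccc(-c2ccc(C(=O)N=C(N)N)cc2S(C)(=O)=O)cc1` gives 100 nM in this assay, and the step of a 2.7-fold higher number from compound 1 to compound 2 (0.43 log units; beyond the scatter) is the only measured change at this position of the core. Compound 3 `CS(=O)(=O)c1cc(C(=O)N=C(N)N)ccc1Br` differs from compound 2 by bromo in place of methoxy on an aromatic carbon. That single step concerns a different group, so it gives only a loose guide. For compound 3 a step of a 1.4-fold lower number from compound 2 to compound 3 (0.13 log units; within the scatter) is expected, within the scatter. Compound 3 is estimated at 200 nM, ranging from 60 nM to 700 nM.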

Compound 3, half-maximal inhibitory concentration: 180 nM
For compound 3 the middle estimate is 1.1-fold (0.05 log units) above the measured one, and the stated range covers the measured number.
By their numbers in this assay, from the lowest: compounds 1, 3 and 2 (each within the scatter of the next, the first and the last beyond it).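

In this assay, bromo and methoxy on this aromatic carbon cannot be told apart (a 1.5-fold lower number from compound 2 to compound 3 (0.18 log units; within the scatter)). Bromo also cannot be separated from 4-methylphenyl (a 1.8-fold higher number from compound 1 to compound 3 (0.26 log units; within the scatter)), although methoxy and 4-methylphenyl do differ beyond the scatter, so compound 3 does not group clearly with either earlier compound. No measurement is available that would explain these numbers.

Going by these compounds, whether an amine, a carboxylic acid or a longer chain at this position would give a number clearly apart from these three remains open.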